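The compounds below may be only part of what the source reports. "The series", "measured", "known", "first", "only" and "open" are said of these compounds alone.

Within the data shown here, in a functional assay on SMMC-7721 cells (Homo sapiens) for cytotoxicity, read by MTT assay, with a stated time of 72 h (a higher number here means a weaker inhibitor, a lower number a stronger inhibitor), compound 1 `[O-][n+]1nc(NCOC2CCCCC2)[n+]([O-])c2ccccc21` gives 28200 nM and compound 2 `CC(C)CCOCNc1n[n+]([O-])c2ccccc2[n+]1[O-]` gives 15900 nM, so compound 2 stands within the scatter of the only other measured compound. Compound 3 `CCCCCOCNc1n[n+]([O-])c2ccccc2[n+]1[O-]` carries propyl in place of isopropyl on a saturated chain carbon, two bonds along the chain from an oxygen on a saturated carbon. Among the measured compounds shown here, the one measured step that bears on this is a 1.8-fold lower number from compound 1 to compound 2 (0.25 log units; within the scatter), where isopentyl takes the place of cyclohexyl on an oxygen on a saturated carbon. On that single step, no change beyond the scatter is expected in this assay. The expected step is a 1.0-fold higher number from compound 2 to compound 3 (0.00 log units; within the scatter). The estimated value for compound 3 is 16000 nM, with an expected range of 8000 nM to 32000 nM.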

Compound 3, half-maximal inhibitory concentration: 17000 nM
Beside the measured number, compound 3's estimate is 1.1-fold (0.03 log units) below it, within the range that was stated.
By their numbers in this assay, from the lowest: compounds 2, 3 and 1 (each within the scatter of the next).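

In this assay, moving from the branched to the straight chain leaves the number within the scatter (a 1.1-fold higher number from compound 2 to compound 3 (0.03 log units; within the scatter)). The pentyl group also stands within the scatter of the cyclohexyl group (a 1.7-fold lower number from compound 1 to compound 3 (0.22 log units; within the scatter)), so the branched, straight and ring groups shown on this oxygen cannot be told apart in this assay. No measurement at hand offers an explanation for this flat result.

As far as these compounds go, whether a longer chain, an amine or a carboxylic acid in place of these groups would move the number beyond the scatter stays open. All three compounds share one core, so changes to it remain unread.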